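Replacing methyl with 2-bromophenyl on the alkene carbon

The source may hold more compounds than are shown below. What is called first, only, known or untested is meant among the compounds shown, and "the series" means these compounds.

Compound 1 `O=C(O)CCCC/C=C(/c1ccc(Br)cc1)c1cccnc1` gives 82 nM in an assay (Equus caballus) for inhibition of Thromboxane-A synthase (Homo sapiens), using microsomes; on this read-out lower numbers stand for stronger inhibition and higher numbers for weaker inhibition. Compound 2 `C/C(=C/CCCCC(=O)O)c1cccnc1` carries methyl where compound 1 carries 4-bromophenyl. In this assay compound 2 gives 71 nM. Of the two numbers, that of compound 2 is the lower one, but the step of a 1.2-fold lower number from compound 1 to compound 2 (0.06 log units; within the scatter) shows the two values lie within the scatter of each other, so no difference between them is established.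

Compound 3 `O=C(O)CCCC/C=C(\c1cccnc1)c1ccccc1Br` has not been measured in this assay. Its change from compound 2 is 2-bromophenyl in place of methyl on a double-bonded chain carbon bound to an aromatic carbon and a double-bonded chain carbon. Going by the values given here, the only step that bears on it runs the other way, from a bromophenyl group to methyl, and it was a 1.2-fold lower number from compound 1 to compound 2 (0.06 log units; within the scatter). On that basis the return to a bromophenyl group, now with bromine in the 2-position, is expected to give no step beyond the scatter, that is a 1.1-fold higher number from compound 2 to compound 3 (0.02 log units; within the scatter). Compound 3 is therefore estimated at 75 nM, within 35 nM to 160 nM.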

Compound 3, half-maximal inhibitory concentration: 130 nM
Estimate against measurement, compound 3: 1.7-fold (0.24 log units) below; the measured number falls inside the stated range.
By their numbers in this assay, from the lowest: compounds 2, 1 and 3 (each within the scatter of the next).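

In this assay the exchange of methyl for 2-bromophenyl on this double-bonded chain carbon is a 1.8-fold higher number from compound 2 to compound 3 (0.26 log units; within the scatter) and stays inside the usual variation, while the exchange of 4-bromophenyl for 2-bromophenyl is a 1.6-fold higher number from compound 1 to compound 3 (0.20 log units; within the scatter) and does the same. Compound 3 thus adds a second bromine placement, and neither the placement of the bromine on the phenyl ring nor the presence of that ring at this carbon is established to change the number among these three compounds. Nothing on hand offers an explanation for these values. The compounds shown leave open whether 3-bromophenyl, unsubstituted phenyl or an amine-bearing group at this carbon would stay with these three or separate from them. They also leave open whether a longer chain in place of methyl would do so.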